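Mirror Image of a Dimethoxy Compound

The compounds below may be only part of what the source reports. "The series", "measured", "known", "first", "only" and "open" are said of these compounds alone.

Compound 1 `COc1ccc([C@]2(CO)NC[C@@H](O)[C@@H]2O)cc1`: 40.2%
Compound 2 `COc1cccc([C@@]2(CO)NC[C@H](O)[C@H]2O)c1`: 46%
Compound 3 `COc1ccc([C@]2(CO)NC[C@@H](O)[C@@H]2O)cc1OC`: 11.1%

In an assay on isolated protein for inhibition of lysosomal alpha-glucosidase (Homo sapiens), tested at 1000 uM (a lower number here means less inhibition, a higher number more inhibition at the concentration tested (going by the name of the read-out)), compound 3 gives the lowest of the three numbers. Among the measured compounds shown here, its nearest neighbour is compound 1, and the step of a number 29.1 percentage points lower from compound 1 to compound 3 (beyond the scatter) is the only measured single change here, a methoxy in place of hydrogen on an aromatic carbon. For the measured compounds named here, compound 2 gives 46%; no single step links it to compound 3, so only the two values can be compared.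

Compound 4 `COc1ccc([C@@]2(CO)NC[C@H](O)[C@H]2O)cc1OC` keeps every atom and bond of compound 3: the two compounds have the same atoms and bonds and differ only in configuration as drawn: 3 of 3 stereo elements differ (all stereocentres are inverted: mirror images); a stereocentre at a saturated ring carbon is drawn R in compound 3 and S in compound 4; a stereocentre at a saturated ring carbon is drawn R in compound 3 and S in compound 4; a stereocentre at a saturated ring carbon is drawn R in compound 3 and S in compound 4. Going by the values given here, no measured pair differs only in configuration, so no measured step bears on this change, and its direction is open. Compound 4 is therefore estimated at 15%, within 0% to 45%, an expected step of a number 3.9 percentage points higher from compound 3 to compound 4 (within the scatter).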

Compound 4, a percentage reported as inhibition, at one concentration (the size of the read-out at that concentration, not a potency): 27.1%
Estimate against measurement, compound 4: 12.1 percentage points below; low and high end bracket the measured number.
By their numbers in this assay, from the lowest: compound 3; then compound 4; then compounds 1 and 2 (each within the scatter of the next).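

Configuration alone moves the number in this assay, a number 16 percentage points higher from compound 3 to compound 4 (beyond the scatter), and no other difference exists to account for it: the fact that compounds 3 and 4 differ only in the configuration as drawn. Methoxy in place of hydrogen on an aromatic carbon also lowers the number on a second core, a number 18.9 percentage points lower from compound 2 to compound 4 (beyond the scatter). The drop seen earlier therefore repeats: the same change on two cores in this assay, a number 29.1 percentage points lower (beyond the scatter) from compound 1 to compound 3 and a number 18.9 percentage points lower (beyond the scatter) from compound 2 to compound 4, 10.2 percentage points apart, within the scatter of two such steps.

Which of the three inverted stereocentres carries the step stays open. So does whether an amine or a carboxylic acid in place of the added methoxy would lower the number too.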